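Swapping the Aryl Group on an Oxazole Ketone Inhibitor

A few compounds are considered here, and "the series" means these few. Any claim that something is new, unique, unknown or untested is made for them only; others in the source may bear on it.

Compound 1 `N#Cc1cccc(-c2cnc(C(=O)CCCCCCc3ccccc3)o2)c1` gives 15 nM in an assay (Rattus norvegicus) for inhibition of Fatty-acid amide hydrolase 1 (Homo sapiens); on this read-out lower numbers stand for stronger inhibition and higher numbers for weaker inhibition. Compound 2 `Nc1ccc(-c2cnc(C(=O)CCCCCCc3ccccc3)o2)cc1` gives 90 nM. Compound 3 `NC(=O)c1ccc(-c2cnc(C(=O)CCCCCCc3ccccc3)o2)cc1` gives 10 nM.

All three share the same core, a phenyl-capped chain on a ketone attached to a five-membered aromatic ring, and differ only in the aryl group on that ring. Compound 3 has the lowest number of the three; the step of a 1.5-fold lower number from compound 1 to compound 3 (0.18 log units; within the scatter) is within the scatter, so those two cannot be ranked. Its gap to compound 2 is clear: a 9.0-fold lower number from compound 2 to compound 3 (0.95 log units; beyond the scatter). The step of a 6.0-fold higher number from compound 1 to compound 2 (0.78 log units; beyond the scatter) shows the same thing from the other side: the amino-bearing analogue falls behind.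

Compound 4 `Cc1cccc(-c2cnc(C(=O)CCCCCCc3ccccc3)o2)n1` has not been measured. Relative to compound 3 the change is 6-methylpyridin-2-yl in place of 4-carbamoylphenyl on an aromatic carbon. For the measured compounds named here, none of the measured steps replaces a carbon ring with a nitrogen-containing one, so the bearing of the known steps is indirect; they only show that the carbamoyl and nitrile analogues sit close together and the amino analogue weaker. On that basis compound 4 is expected to stay near compound 3, with an estimated step of a 1.3-fold lower number from compound 3 to compound 4 (0.10 log units; within the scatter) in this assay, not beyond the scatter. Compound 4 is therefore estimated at 8 nM, in a range from 2.5 nM to 25 nM.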

Compound 4, inhibition constant: 3.3 nM
The estimate for compound 4 lay 2.4-fold (0.38 log units) above the measured number; low and high end bracket the measured number.
By their numbers in this assay, from the lowest: compound 4; then compounds 3 and 1 (each within the scatter of the next); then compound 2.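

At this position, next to the ring oxygen, the aryl ring need not be carbon only, nor carry a hydrogen-bond donor, to give a low number in this assay: 6-methylpyridin-2-yl, with one hetero atom in its ring, improves on 4-carbamoylphenyl (a 3.0-fold lower number from compound 3 to compound 4 (0.48 log units; beyond the scatter)). The same group also improves on 3-cyanophenyl (a 4.5-fold lower number from compound 1 to compound 4 (0.66 log units; beyond the scatter)) and on 4-aminophenyl (a 27-fold lower number from compound 2 to compound 4 (1.44 log units; beyond the scatter)), and this last step is the largest among the four compounds. The earlier compounds shown here reached a floor at which compound 1 and compound 3 could not be told apart, whereas compound 4 lies beyond the scatter from all three others and is therefore the strongest inhibitor of the set.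

No measurement on hand explains why this group gives the lower number. The change replaces the ring and its substituent together, so the ring nitrogen and the methyl group cannot be credited separately; plain pyridin-2-yl without the methyl, or a phenyl ring carrying a methyl group, would begin to separate the two.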